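Notes on compound 1 and a carbamoyl analogue

The source may report more compounds than this note shows. Statements on the series, on what has been measured and on what is new or still open speak of the compounds shown alone.

In a functional assay on MCF7 cells (Homo sapiens) for antiproliferative activity, read by MTT assay, with a stated time of 48 h (a higher number here means a weaker inhibitor, a lower number a stronger inhibitor), compound 1 `CC(C)=CCC[C@]1(C)/C=C/[C@@H](OC(=O)C=C(C)C)[C@](C)(O)/C=C/C(=O)/C(CCl)=C\C1` gives 610 nM, the lowest of the two numbers recorded so far. Among the compounds with values here, compound 2 `CC(C)=CCC[C@]1(C)/C=C/[C@@H](OC(=O)C=C(C)C)[C@](C)(O)/C=C/C(O)/C(C=O)=C\C1` gives 2320 nM in this assay, a higher number that lies beyond the scatter; compound 2 differs from compound 1 in more than one place, so no single step joins them. Compound 3 `CC(C)=CCC[C@]1(C)/C=C/[C@@H](OC(=O)C=C(C)C)[C@](C)(O)/C=C/C(=O)/C(C(=O)N(C)C)=C\C1` is not yet measured. Against compound 1 it shows (dimethylcarbamoyl in place of chloromethyl on a double-bonded ring carbon). In this assay a step upward from compound 1 to compound 3, beyond the scatter, is expected. Compound 3 is estimated at 3000 nM, between 700 nM and 13000 nM. That estimate means an expected step of a 4.9-fold higher number from compound 1 to compound 3 (0.69 log units; beyond the scatter).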

Compound 3, half-maximal inhibitory concentration: 3670 nM
For compound 3 the middle estimate is 1.2-fold (0.09 log units) below the measured one; low and high end bracket the measured number.
By their numbers in this assay, from the lowest: compound 1; then compounds 2 and 3 (each within the scatter of the next).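

In this assay, within the data shown here, dimethylcarbamoyl in place of chloromethyl on a double-bonded ring carbon gives a 6.0-fold higher number from compound 1 to compound 3 (0.78 log units; beyond the scatter) as the first single-place step. This position is therefore not indifferent to the group it carries, and of these two groups chloromethyl gives the lower number. No measurement available here accounts for this step.

On these data alone, whether the higher number follows from losing chloromethyl or from introducing dimethylcarbamoyl remains open. Hydroxymethyl, bromomethyl or a primary carboxamide at this place would help to separate the two readings.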